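Toward a benzotriazolyl ester on the furan carboxylate

A few compounds are considered here, and "the series" means these few. Any claim that something is new, unique, unknown or untested is made for them only; others in the source may bear on it.

Compound 2 `CCCOC(=O)c1c(C)coc1-c1ccc2c(CC)cccc2c1OC` is the propyl ester of the shared core. In a functional assay on A549 cells (Homo sapiens) for cytotoxicity, read by MTT assay, with a stated time of 72 h (a higher number here means that more compound is needed for the effect, a lower number that less compound is needed), compound 2 gives only a limit, > 10 ug/mL. Its neighbours fix its place: compound 1 `CCc1cccc2c(OC)c(-c3occ(C)c3C(=O)OC)ccc12` gives 1.5 ug/mL, and compound 3 `CCc1cccc2c(OC)c(-c3occ(C)c3C(=S)OC)ccc12` gives 6.2 ug/mL. Compound 4 `CCc1cccc2c(OC)c(-c3occ(C)c3C(=O)On3nnc4ccccc43)ccc12` differs from compound 2 by a group of 9 heavy atoms (6 carbon, 3 nitrogen; one five-membered aromatic ring with 3 hetero atoms, one six-membered aromatic ring of carbon only) in place of a group of 3 heavy atoms (3 carbon; no ring), on an oxygen next to a carbonyl group. For the measured compounds named here, two measured steps touch this ester position: an at least 6.6-fold higher number from compound 1 to compound 2 (0.82 log units; beyond the scatter), and an at least 1.6-fold lower number from compound 2 to compound 3 (0.20 log units; that floor lies within the scatter). The first shows that a longer chain on that oxygen went with a higher number; the second, the propyl ester being replaced, points only weakly lower. A still larger group entering there therefore carries no firm direction, and the number for compound 4 is expected near 6 ug/mL, between 1.5 ug/mL and 25 ug/mL, that is an at least 1.6-fold lower number from compound 2 to compound 4 (0.22 log units; that floor lies within the scatter).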

Compound 4, concentration for half-maximal effect: > 10 ug/mL
Compound 4: a limit, no number; the forecaster's own chance of this, stated with the estimate: 35%; at least 1.6-fold (0.22 log units) between middle value and limit.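

In this assay compound 4 gives only a limit, as compound 2 does, and the step between them cannot be read because both stop at that limit: the limit of > 10 ug/mL in this assay, at which 2 of the 4 values shown sit. Against the methyl ester, the group of 9 heavy atoms on this oxygen gives an at least 6.6-fold higher number from compound 1 to compound 4 (0.82 log units; beyond the scatter). A group with aromatic rings here, like propyl, thus does not return to the 1.5 ug/mL of compound 1.

On these data alone, how propyl and the new group rank remains open. Also open, as far as these compounds go, is whether an ethyl ester or an amide at this carbonyl would stay close to compound 1.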